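The source may hold more compounds than are shown below. What is called first, only, known or untested is meant among the compounds shown, and "the series" means these compounds.

Among the compounds with values here, compound 2 `COc1ccc(-c2csc(NC(=O)COc3ccc(C(=O)c4ccc(F)cc4)cc3C)n2)cc1` gives 5200 nM in a functional assay on Ehrlich cells (Mus musculus) for cytotoxicity, read by trypan blue exclusion, with a stated time of 48 h (on this read-out higher numbers stand for weaker inhibition and lower numbers for stronger inhibition), the lower of the two numbers measured so far; compound 1 `COc1ccc(-c2csc(NC(=O)COc3ccc(C(=O)c4ccc(C)cc4)cc3C)n2)cc1` gives 19400 nM. Within the data shown here, the only measured step, a 3.7-fold lower number from compound 1 to compound 2 (0.57 log units; beyond the scatter), concerns a different change and says nothing about where the fluorine sits. Compound 3 `COc1ccc(-c2csc(NC(=O)COc3ccc(C(=O)c4cccc(F)c4)cc3C)n2)cc1` differs from compound 2 by 3-fluorophenyl in place of 4-fluorophenyl on a carbonyl carbon, so the two have the same atoms, joined differently. Among the measured compounds shown here, with no step of this kind measured, the expected change is a 1.1-fold higher number from compound 2 to compound 3 (0.02 log units; within the scatter), within the usual scatter. Compound 3 is therefore estimated at 5500 nM, with a likely range from 2000 nM to 15000 nM.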

Compound 3, half-maximal inhibitory concentration: 29500 nM
For compound 3 the middle estimate is 5.4-fold (0.73 log units) below the measured one, and the stated range ends below it.
By their numbers in this assay, from the lowest: compound 2; then compounds 1 and 3 (each within the scatter of the next).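

In this assay, the position of the fluorine on this ring matters: 3-fluorophenyl in place of 4-fluorophenyl on a carbonyl carbon gives a 5.7-fold higher number from compound 2 to compound 3 (0.75 log units; beyond the scatter) even though the atoms stay the same. Having a fluorine on this ring is therefore not enough for the lower number, as 3-fluorophenyl in place of 4-methylphenyl gives only a 1.5-fold higher number from compound 1 to compound 3 (0.18 log units; within the scatter) and stays within the scatter. No measurement here explains why the position matters. On these data alone, it remains open whether a chlorophenyl or an aminophenyl group on the same carbonyl carbon would also depend on position.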